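A few compounds are considered here, and "the series" means these few. Any claim that something is new, unique, unknown or untested is made for them only; others in the source may bear on it.

Compound 1 `Cc1noc(C)c1-c1cnc(N)c(Oc2ccc(C(=O)NC3CC3)cc2)n1` gives 17800 nM in a functional assay on HeLa cells (Homo sapiens) for inhibition, read by MTT assay, with a stated time of 72 h; on this read-out lower numbers stand for stronger inhibition and higher numbers for weaker inhibition. Compound 2 `Cc1noc(C)c1-c1cnc(N)c(Oc2ccc(C(=O)NC3CCCCC3)cc2)n1` gives 26100 nM. Compound 3 `Cc1noc(C)c1-c1cnc(N)c(Oc2ccc(C(=O)Nc3ccccc3)cc2)n1` gives 10500 nM.

Compound 3 has the lowest of the three numbers: the step of a 1.7-fold lower number from compound 1 to compound 3 (0.23 log units; within the scatter) stays within the scatter, whereas the step of a 2.5-fold lower number from compound 2 to compound 3 (0.40 log units; beyond the scatter) is modest but beyond it. Compound 4 `Cc1noc(C)c1-c1cnc(N)c(Oc2ccc(C(=O)Nc3ccccc3Cl)cc2)n1` differs from compound 3 by chloro in place of hydrogen on an aromatic carbon. Among the measured compounds shown here, none of the measured steps covers such an addition; each of them, including a 1.5-fold higher number from compound 1 to compound 2 (0.17 log units; within the scatter), exchanges the whole group on the amide-type nitrogen rather than decorating the phenyl ring. No step beyond the scatter is expected in this assay, and the estimated change is a 1.1-fold lower number from compound 3 to compound 4 (0.02 log units; within the scatter). Compound 4 is therefore estimated at 10000 nM, with a range from 4000 nM to 25000 nM.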

Compound 4, half-maximal inhibitory concentration: 81300 nM
Beside the measured number, compound 4's estimate is 8.1-fold (0.91 log units) below it; the measured number lies above the stated range.
By their numbers in this assay, from the lowest: compounds 3, 1 and 2 (each within the scatter of the next, the first and the last beyond it); then compound 4.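

The earlier compounds shown here only exchanged the whole group on the amide-type nitrogen, whereas this change adds to the phenyl ring itself: one chloro, ortho to a large group, gives a clear loss of inhibition (a 7.7-fold higher number from compound 3 to compound 4 (0.89 log units; beyond the scatter)). Compound 4 also falls behind the cyclopropyl amide (a 4.6-fold higher number from compound 1 to compound 4 (0.66 log units; beyond the scatter)) and the cyclohexyl amide (a 3.1-fold higher number from compound 2 to compound 4 (0.49 log units; beyond the scatter)), so here a single added atom outweighs the benefit of an aromatic ring on that nitrogen. Nothing available explains this loss.

The compounds shown leave open whether the loss belongs to chloro itself or to its place on the ring. Fluoro or methyl on the same carbon, or chloro elsewhere on the ring, would separate the two.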